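The source may hold more compounds than are shown below. What is called first, only, known or untested is meant among the compounds shown, and "the series" means these compounds.

Measured in a functional assay on A2780 cells (Homo sapiens) for antiproliferative activity, read by sulforhodamine B assay, with a stated time of 72 h; a lower number here means a stronger inhibitor, a higher number a weaker inhibitor:

- Compound 1 `O=C(NCc1ccc(Cl)nc1)Nc1ccc(S(=O)(=O)c2ccccc2)cc1`: > 2000 nM, a limit of the assay and not a number
- Compound 2 `C[C@@H]1CN(S(=O)(=O)c2ccc(NC(=O)NCc3cccnc3)cc2)C[C@H](C)O1`: 15 nM

Within the data shown here, compound 2 holds the only actual number in this assay, at 15 nM. Compound 1 gives only a limit, > 2000 nM.

Compound 3 `N[C@H]1CC[C@H](NS(=O)(=O)c2ccc(NC(=O)NCc3cccnc3)cc2)CC1` changes a single place in compound 2: (4-aminocyclohexyl)amino in place of 2,6-dimethylmorpholin-4-yl on a sulfonyl sulfur. Here (4-aminocyclohexyl)amino takes the place of 2,6-dimethylmorpholin-4-yl on a sulfonyl sulfur. Among the measured compounds shown here, no measured pair of compounds shows a swap of this kind, so the size of the step has to be judged without a direct precedent. With compound 2 at 15 nM as the only firm reference, a moderate weakening somewhat beyond the usual scatter is expected, and the uncertainty is wide. The expected change is a 4.0-fold higher number from compound 2 to compound 3 (0.60 log units; beyond the scatter). For compound 3 the estimate is 60 nM, with an expected range of 10 nM to 400 nM.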

Compound 3, half-maximal inhibitory concentration: 52 nM
Compound 3: the middle estimate sits 1.2-fold (0.06 log units) above what was measured; the measured number falls inside the stated range.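

In this assay, replacing 2,6-dimethylmorpholin-4-yl with (4-aminocyclohexyl)amino on a sulfonyl sulfur gives a 3.5-fold higher number from compound 2 to compound 3 (0.54 log units; beyond the scatter). This first measured change at this place shows that the group can be exchanged for one with a carbon-only ring and hydrogen-bond donors, which the leaving group lacks, at a modest cost: compound 3 still reads 52 nM. Nothing measured here explains the size of this step.

The swap alters the ring atoms, the link to the sulfur and the amino group together, so the part responsible for the step remains unresolved. On these data alone, it also remains open how a simple open-chain amine on the sulfonyl sulfur, or a carboxylic acid in place of the amino group of compound 3, would read.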